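A few compounds are considered here, and "the series" means these few. Any claim that something is new, unique, unknown or untested is made for them only; others in the source may bear on it.

Measured in a functional assay on SK-OV-3 cells (Homo sapiens) for inhibition, read by MTT assay; a higher number here means a weaker inhibitor, a lower number a stronger inhibitor:
- Compound 1 `COc1ccc(/C=C2\c3cc(OC)c(OC)c(OC)c3CC[C@@H]2O)cc1C#N`: 20 nM
- Compound 2 `COc1ccc(/C=C2\c3cc(OC)c(OC)c(OC)c3CC[C@@H]2O)cc1O`: 1060 nM

Of the two, compound 2 has the higher number, 1060 nM, and so is the weaker inhibitor. Compound 3 `COc1ccc(/C=C2\c3cc(OC)c(OC)c(OC)c3CC[C@@H]2O)cc1C(N)=O` keeps the shared core and changes one group: carbamoyl in place of hydroxy on an aromatic carbon. This puts carbamoyl in place of hydroxy on an aromatic carbon, ortho to a methoxy group. Going by the values given here, only one measured step bears on this place: a 53-fold higher number from compound 1 to compound 2 (1.72 log units; beyond the scatter). That step is large and beyond the scatter, so the readout in this assay can respond strongly to the group here. Among the compounds with values here, no carbamoyl compound has been measured, however, so the step does not fix a direction for the new change. The expected change is a 1.5-fold lower number from compound 2 to compound 3 (0.18 log units; within the scatter), which would not clearly exceed the scatter. For compound 3 the estimated value is 700 nM, with an expected range of 120 nM to 4000 nM.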

Compound 3, half-maximal inhibitory concentration: 1440 nM
Compound 3: middle estimate off by 2.1-fold (0.31 log units), on the low side; the range from low to high includes it.
By their numbers in this assay, from the lowest: compound 1; then compounds 2 and 3 (each within the scatter of the next).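

In this assay, carbamoyl in place of hydroxy on an aromatic carbon gives a 1.4-fold higher number from compound 2 to compound 3 (0.13 log units; within the scatter) and so cannot be told apart from hydroxy at this position. Carbamoyl in place of cyano gives a 72-fold higher number from compound 1 to compound 3 (1.86 log units; beyond the scatter), which shows that the large gap first seen with hydroxy also appears with a second replacement; among the three groups, the nitrile of compound 1 alone stands apart, with steps to both others beyond the scatter. The data on hand include nothing that accounts for this gap.

On these data alone, it remains open whether any group other than the nitrile, such as an amine, a carboxylic acid or a methyl ester, can bring a compound close to compound 1 at 20 nM. As far as these compounds go, whether the same gap appears in other cell lines also remains open.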